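The compounds below may be only part of what the source reports. "The series", "measured", "known", "first", "only" and "open" are said of these compounds alone.

Compound 3 `CC(C)Sc1nnc(-c2c(CNC3CC3)c3ccccc3n2C)n1-c1ccccc1` carries the lowest number among the three measured compounds: in a physicochemical assay for lipophilicity (on this read-out higher numbers stand for higher lipophilicity and lower numbers for lower lipophilicity), compound 3 gives 4.81. Its nearest neighbour is compound 2 `CC1CCCN(Cc2c(-c3nnc(SC(C)C)n3-c3ccccc3)n(C)c3ccccc23)C1`, for which compound 2 gives 6.03, and the furthest is compound 1 `COc1cccc(CNCc2c(-c3nnc(SC(C)C)n3-c3ccccc3)n(C)c3ccccc23)c1`, where compound 1 gives 6.27. Both measured steps that reach compound 3 alter the same part of the molecule, the group on the amine nitrogen or the whole group on the saturated chain carbon bound to an aromatic carbon: a number 1.46 log units lower from compound 1 to compound 3 (beyond the scatter) and a number 1.22 log units lower from compound 2 to compound 3 (beyond the scatter). The third step, a number 0.24 log units lower from compound 1 to compound 2 (within the scatter), lies within the scatter.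

Compound 4 `CC(C)Sc1nnc(-c2c(CNc3cnccn3)c3ccccc3n2C)n1-c1ccccc1` differs from compound 3 at exactly this amine nitrogen: pyrazin-2-yl in place of cyclopropyl on an amine nitrogen. The measured steps show that exchanging the group on this nitrogen moves the read-out by a large amount, yet none of them places a six-membered aromatic ring with two hetero atoms there, so the direction cannot be read off directly. Weighing the counted difference, a six-membered aromatic ring with two hydrogen-bond acceptors entering for a three-membered ring of carbon only, the expectation is a moderate fall, a number 0.41 log units lower from compound 3 to compound 4 (beyond the scatter). Compound 4 is therefore estimated at 4.4, within a range from 3.7 to 5.1.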

Compound 4, partition coefficient: 4.22
Estimate against measurement, compound 4: 0.18 log units above, and the stated range covers the measured number.
By their numbers in this assay, from the lowest: compound 4; then compound 3; then compounds 2 and 1 (each within the scatter of the next).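

In this assay, pyrazin-2-yl in place of cyclopropyl on the amine nitrogen gives a number 0.59 log units lower from compound 3 to compound 4 (beyond the scatter), so this position can go lower than cyclopropyl, which had held the lowest number until now. The read-out here does not simply follow the size of the group: the earlier step with cyclopropyl in place of 3-methoxybenzyl could be read as smaller meaning lower, yet pyrazin-2-yl brings 6 heavy atoms in place of 3 and the number still falls. The span at this site also widens, with a number 2.05 log units lower from compound 1 to compound 4 (beyond the scatter) for the exchange on the amine nitrogen and a number 1.81 log units lower from compound 2 to compound 4 (beyond the scatter) for the exchange of the whole group on the saturated chain carbon, and nothing available explains why the read-out moves as it does.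

The compounds shown leave open whether the fall goes with the aromatic ring itself or with its ring nitrogens, and a phenyl or a pyridin-2-yl on this amine nitrogen would separate the two readings. Where an open chain such as 2-methoxyethyl would fall relative to these ring groups also remains unknown.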